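The source may hold more compounds than are shown below. What is called first, only, known or untested is meant among the compounds shown, and "the series" means these compounds.

Compound 1 `C=CC[C@H]1C[C@]2([C@@H](C)Cc3ccc(OC)cc3)OCOC2=CC1=O`: 20 nM
Compound 2 `C=CC[C@H]1C[C@]2([C@@H](C)Cc3cccc(OC)c3)OCOC2=CC1=O`: 8800 nM
Compound 3 `C=CC[C@H]1C[C@]2([C@@H](C)Cc3ccc(OC(F)(F)F)cc3)OCOC2=CC1=O`: > 20000 nM

Of the compounds shown here, three that share one core have been tested in a functional assay on M14 cells (Homo sapiens) for antiproliferative activity, with a stated time of 72 h; on this read-out lower numbers stand for stronger inhibition and higher numbers for weaker inhibition. Compound 1 gives 20 nM, the lowest of the numbers shown. Moving the methoxy group around the ring gave a 440-fold higher number from compound 1 to compound 2 (2.64 log units; beyond the scatter). For compound 3 the assay reports only a limit, > 20000 nM, because the value sits at the limit of > 20000 nM in this assay, at which 1 of the 3 values shown sits. That change gave an at least 1000-fold higher number from compound 1 to compound 3 (3.00 log units; beyond the scatter). Compound 4 `C=CC[C@H]1C[C@]2([C@@H](C)Cc3ccc(OC)c(C#N)c3)OCOC2=CC1=O` differs from compound 1 by cyano in place of hydrogen on an aromatic carbon. Both measured steps touched the same aromatic ring and were large, so a change on that ring is expected to raise the number again, though the methoxy group itself is kept; the expected step is a 15-fold higher number from compound 1 to compound 4 (1.18 log units; beyond the scatter). Compound 4 is therefore estimated at 300 nM, within 30 nM to 5000 nM.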

Compound 4, half-maximal inhibitory concentration: 180 nM
For compound 4 the middle estimate is 1.7-fold (0.22 log units) above the measured one, and the stated range covers the measured number.
By their numbers in this assay, from the lowest: compound 1; then compound 4; then compound 2. At a limit, above all of these: compound 3.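

Placing cyano on the aromatic carbon ortho to a methoxy group, with that methoxy group left intact, gave a 9.0-fold higher number from compound 1 to compound 4 (0.95 log units; beyond the scatter). This weakens inhibition, but the step is smaller than either earlier change on this ring, both of which moved or altered the methoxy group, so this carbon tolerates a new group fairly well. Nothing measured here explains the size of this step. Open, on these data alone, is whether fluorine, an amine or a carboxylic acid on this same aromatic carbon would give a number closer to that of compound 1 or further from it.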